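From compound 3 to compound 4: nitrogen substituent swap

The source may report more compounds than this note shows. Statements on the series, on what has been measured and on what is new or still open speak of the compounds shown alone.

Measured so far in a functional assay on DU-145 cells (Homo sapiens) for cytotoxicity, read by trypan blue exclusion, with a stated time of 96 h; on this read-out higher numbers stand for weaker inhibition and lower numbers for stronger inhibition
- compound 1 `COc1cc(OC)c(/C=C/S(=O)(=O)Cc2ccc(OC)c(N)c2)c(OC)c1` gives 4 nM
- compound 2 `COC(=O)CNc1cc(CS(=O)(=O)/C=C/c2c(OC)cc(OC)cc2OC)ccc1OC` gives 100 nM
- compound 3 `COC(=O)C(C)(C)Nc1cc(CS(=O)(=O)/C=C/c2c(OC)cc(OC)cc2OC)ccc1OC` gives 2500 nM

Compound 3 has the highest number of the three and is the weakest here, with its steps to both others beyond the scatter. In compound 4 `COC(=O)C(Nc1cc(CS(=O)(=O)/C=C/c2c(OC)cc(OC)cc2OC)ccc1OC)c1ccc(F)cc1` the core stays and the group on the nitrogen changes ((4-fluorophenyl)(methoxycarbonyl)methyl in place of 1-(methoxycarbonyl)-1-methylethyl on a nitrogen on an aromatic ring).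

Substituting the hydrogen on that nitrogen gave a 25-fold higher number from compound 1 to compound 2 (1.40 log units; beyond the scatter) and a 630-fold higher number from compound 1 to compound 3 (2.80 log units; beyond the scatter) in this assay as measured. The closest guide is a 25-fold higher number from compound 2 to compound 3 (1.40 log units; beyond the scatter) on exchanging (methoxycarbonyl)methyl for 1-(methoxycarbonyl)-1-methylethyl. Among the compounds with values here, no measured compound carries an aromatic ring in this group, so the size of the next step is poorly constrained. A partial return towards compound 2 at 100 nM is expected, with a lower number and not a full recovery. For compound 4 the expected step is a 6.3-fold lower number from compound 3 to compound 4 (0.80 log units; beyond the scatter) on this reasoning. The estimated value for compound 4 is 400 nM (expected range 60 nM to 2500 nM).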

Compound 4, half-maximal inhibitory concentration: 300 nM
The estimate for compound 4 lay 1.3-fold (0.12 log units) above the measured number; the measured number falls inside the stated range.
By their numbers in this assay, from the lowest: compound 1; then compound 2; then compound 4; then compound 3.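

In this assay, this nitrogen accepts a group carrying an aromatic ring without a further rise in the number: (4-fluorophenyl)(methoxycarbonyl)methyl in place of 1-(methoxycarbonyl)-1-methylethyl gives (an 8.3-fold lower number from compound 3 to compound 4 (0.92 log units; beyond the scatter)) even though the entering group has more heavy atoms, so the number does not simply follow group size, and compound 4 goes against the rise seen through compound 1, compound 2 and compound 3. The 4-fluorophenyl on the saturated chain carbon still costs against hydrogen there (a 3.0-fold higher number from compound 2 to compound 4 (0.48 log units; beyond the scatter)), and the whole substituent costs more against hydrogen on the nitrogen (a 75-fold higher number from compound 1 to compound 4 (1.88 log units; beyond the scatter)). Nothing available bears on the cause of these steps.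

Open, from the compounds shown here alone, is whether plain phenyl would read like 4-fluorophenyl. Also open, going by these compounds, is what a carboxylic acid in place of the methoxycarbonyl would give at this position.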